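This account rests on a few compounds, and the source may have more. Where it says the series, first, only, none or still open, it means among the compounds named here.

The measured compounds:

Compound 1 `O=C(CSc1snnc1-c1ccc(Br)cc1Br)Nc1ccccc1[N+](=O)[O-]` gives > 235000 nM in an ADME assay on MT4 cells (Homo sapiens) for cytotoxicity, read by MTT assay, with a stated time of 5 days (a higher number here means that more compound is tolerated, a lower number that less compound is tolerated), which is a limit of the assay.
Compound 2 `O=C(CSc1snnc1-c1ccc(Br)cc1Br)Nc1cccnc1Cl` gives > 240000 nM in this assay, also a limit.
Compound 3 `O=C(CSc1snnc1-c1ccc(Br)cc1Br)Nc1nccs1` gives 87800 nM in this assay.

Compound 3 therefore stands as the only one of the three with an actual number; the other two sit at limits (the limit of > 235000 nM in this assay, at which 1 of the 3 values shown sits, and (the limit of > 240000 nM in this assay, at which 1 of the 3 values shown sits)). Its steps from the two others are an at least 2.6-fold lower number from compound 1 to compound 3 (0.42 log units; beyond the scatter) and an at least 2.7-fold lower number from compound 2 to compound 3 (0.43 log units; beyond the scatter), both beyond the scatter, while a step that the two limits leave unreadable from compound 1 to compound 2 cannot be read.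

Compound 4 `Cc1ccc(NC(=O)CSc2snnc2-c2ccc(Br)cc2Br)c(Br)c1` differs from compound 3 in one place: 2-bromo-4-methylphenyl in place of 1,3-thiazol-2-yl on an amide-type nitrogen. This moves the group on the amide nitrogen away from the 1,3-thiazol-2-yl of compound 3 and back toward something more like the 2-nitrophenyl of compound 1 and the 2-chloropyridin-3-yl of compound 2, both of which tolerated more compound than compound 3. The two readable steps bear on this change in reverse: leaving the thiazolyl for such a ring should raise the number by at least as much as they fell. The expected step in this assay is therefore an increase, a 2.3-fold higher number from compound 3 to compound 4 (0.36 log units; beyond the scatter), quite possibly ending at a limit again. Compound 4 is estimated at 200000 nM, expected to fall between 80000 nM and 300000 nM.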

Compound 4, half-maximal cytotoxic concentration: > 216000 nM
Compound 4: no number, only a limit; the forecaster's own chance of this, stated with the estimate: 60%; at least 1.0-fold (0.03 log units) between middle value and limit.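

In this assay, compound 4 gives no number, only a limit: the limit of > 216000 nM in this assay, at which 1 of the 4 values shown sits. Replacing the 1,3-thiazol-2-yl on the amide-type nitrogen with 2-bromo-4-methylphenyl gives an at least 2.4-fold higher number from compound 3 to compound 4 (0.39 log units; beyond the scatter), a step beyond the scatter that runs opposite to the two earlier steps into compound 3. Until now, the lower number of compound 3 had been set against only the 2-nitrophenyl of compound 1 and the 2-chloropyridin-3-yl of compound 2, and a third, differently substituted six-membered aromatic ring now also ends at a limit, leaving compound 3 as the only one of the four with an actual number.

The steps among compound 1, compound 2 and compound 4 cannot be read, since each joins two limits, so these three rings cannot be placed in any order. On these data alone, it remains open whether the lower number of compound 3 belongs to the 1,3-thiazol-2-yl alone or to five-membered aromatic rings more widely, and how a cyclohexyl group or a phenyl ring carrying a carboxylic acid would behave on this nitrogen.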